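Difluoro-2-nitrophenyl isomers at the assay limit

This account rests on a few compounds, and the source may have more. Where it says the series, first, only, none or still open, it means among the compounds named here.

In a functional assay on CCRF-CEM cells (Homo sapiens) for cytotoxicity, in the absence of a further agent (on this read-out higher numbers stand for weaker inhibition and lower numbers for stronger inhibition), compound 1 `COC(=O)c1ccc(CN(CCCc2c(N)nc(N)nc2O)c2cc(F)cc(F)c2[N+](=O)[O-])cc1` gives > 100000 nM as a limit and not a number. Within the data shown here, compound 1 thereby stands at the limit of > 100000 nM in this assay, at which 1 of the 3 values shown sits, so far. In this assay compound 2 `CC(C)(C)OC(=O)CCC(Nc1ccc(CN(CCCc2c(N)nc(N)nc2O)c2ccc([N+](=O)[O-])c(F)c2[N+](=O)[O-])cc1)C(=O)OC(C)(C)C` gives 3900 nM and compound 3 `CC(C)(C)OC(=O)CCC(Nc1ccc(CN(CCCc2c(N)nc(N)nc2O)c2cc(F)c([N+](=O)[O-])cc2[N+](=O)[O-])cc1)C(=O)OC(C)(C)C` gives 1500 nM as measured numbers, but neither connects to compound 1 through a measured single change. The change to compound 4 `COC(=O)c1ccc(CN(CCCc2c(N)nc(N)nc2O)c2cc(F)c(F)cc2[N+](=O)[O-])cc1` is 4,5-difluoro-2-nitrophenyl in place of 3,5-difluoro-2-nitrophenyl on an amine nitrogen with the same atoms joined differently. Among the measured compounds shown here, no measured step guides this change, so only a modest shift towards stronger inhibition is expected, and another limit is quite possible. The expected size is an at least 1.6-fold lower number from compound 1 to compound 4 (0.22 log units; that floor lies within the scatter) on this estimate. Estimated for compound 4 is 60000 nM with an expected range from 15000 nM to 100000 nM in this read-out.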

Compound 4, half-maximal inhibitory concentration: 66000 nM
For compound 4 the middle estimate is 1.1-fold (0.04 log units) below the measured one, within the range that was stated.
By their numbers in this assay, from the lowest: compound 3; then compound 2; then compound 4. At a limit, above all of these: compound 1.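

On the amine nitrogen, 4,5-difluoro-2-nitrophenyl in place of 3,5-difluoro-2-nitrophenyl gives an at least 1.5-fold lower number from compound 1 to compound 4 (0.18 log units; that floor lies within the scatter) in this assay. Among these compounds, this is the first single change that can be read, and it shows that rearranging the same atoms at this position can bring the value within measurable range. The step is only a floor and lies within the scatter, because one of its ends is a limit: the limit of > 100000 nM in this assay, at which 1 of the 4 values shown sits.

Still open, as far as these compounds go, is whether a carboxylic acid in place of the methyl ester shifts the number. Compound 2 and compound 3 differ from compound 4 in more than one place, so they cannot be compared with it.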